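Aromatic halogen substitution and cytotoxicity in a short series

This account rests on a few compounds, and the source may have more. Where it says the series, first, only, none or still open, it means among the compounds named here.

Compound 1 `OCCCCCC(O)c1ccc(-c2ccccc2)cc1` gives 22000 nM in a functional assay on J774 cells (Mus musculus) for cytotoxicity, read by resazurin assay; on this read-out lower numbers stand for stronger inhibition and higher numbers for weaker inhibition. Compound 2 `OCCCCCC(O)c1ccc(-c2ccc(F)cc2)cc1` gives 18000 nM in this assay; the step is a 1.2-fold lower number from compound 1 to compound 2 (0.09 log units; within the scatter). Compound 3 `OCCCCCC(O)c1ccc(-c2ccc(Cl)cc2)cc1` carries chloro in place of hydrogen on an aromatic carbon and gives 17000 nM in this assay; the steps of a 1.3-fold lower number from compound 1 to compound 3 (0.11 log units; within the scatter) and a 1.1-fold lower number from compound 2 to compound 3 (0.02 log units; within the scatter) are both within the scatter, so the three numbers are not separated. Compound 4 `OCCCCCC(O)c1ccc(-c2ccc(F)cc2)cc1Cl` is not yet measured. Within the data shown here, it differs from compound 2 by chloro in place of hydrogen on an aromatic carbon, the same kind of change as the one made from compound 1 to compound 3, but ortho to a group of 8 heavy atoms and meta to a 4-fluorophenyl group rather than para to a large group. The cores of compound 2 and compound 4 differ from that of compound 1 by fluoro in place of hydrogen on an aromatic carbon. Beside the earlier 1.3-fold lower number from compound 1 to compound 3 (0.11 log units; within the scatter), the new step is expected to be a 1.2-fold lower number from compound 2 to compound 4 (0.08 log units; within the scatter), because a 1.3-fold lower number from compound 1 to compound 3 (0.11 log units; within the scatter) stayed within the scatter. Compound 4 is therefore estimated at 15000 nM, between 7000 nM and 32000 nM.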

Compound 4, half-maximal inhibitory concentration: 8000 nM
The estimate for compound 4 lay 1.9-fold (0.27 log units) above the measured number; low and high end bracket the measured number.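

In this assay, chloro in place of hydrogen, ortho to a group of 8 heavy atoms and meta to a 4-fluorophenyl group, gives a 2.3-fold lower number from compound 2 to compound 4 (0.35 log units; beyond the scatter). Set beside the earlier step, the change is not shown to differ between the two cores, even though only the newer step lies beyond the scatter: the same change on two cores in this assay, a 1.3-fold lower number (0.11 log units; within the scatter) from compound 1 to compound 3 and a 2.3-fold lower number (0.35 log units; beyond the scatter) from compound 2 to compound 4, 1.7-fold (0.24 log units) apart, within the scatter of two such steps

Among these compounds, with only two steps, and the chloro at a different place in each, the data do not show whether the core or the place sets the size of the step. Still open, from the compounds shown here alone, is what chloro does on the core of compound 1 at the place it holds in compound 4. Also open, going by these compounds, is whether a methoxy group or an amine at that place, or a longer chain, would shift the number in the same way.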